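Removing the Fluoro from Compound 3: Affinity Outlook

This account rests on a few compounds, and the source may have more. Where it says the series, first, only, none or still open, it means among the compounds named here.

Of the compounds shown here, three sharing one core have been measured for binding to the serotonin receptor in question. Compound 1 has the structure `Clc1ccc(-c2n[nH]cc2N2CCCNCC2)cc1`. In an assay on isolated protein for binding affinity to 5-hydroxytryptamine receptor 4 (Homo sapiens) (on this read-out higher numbers stand for weaker inhibition and lower numbers for stronger inhibition), compound 1 gives > 10000 nM, which is a limit of the assay rather than a number. Compound 2, `Fc1cccc(-c2n[nH]cc2N2CCCNCC2)c1`, gives > 10000 nM in this assay, again a limit. Compound 3, `Fc1ccc(-c2n[nH]cc2N2CCCNCC2)cc1`, gives > 10000 nM in this assay, also a limit. All three values therefore sit at the limit of > 10000 nM in this assay, at which 3 of the 3 values shown sit, so nothing can be ranked among them.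

One single-point comparison exists: a step that the two limits leave unreadable from compound 1 to compound 3, a step whose size cannot be read because both ends are limits.

Compound 4, `c1ccc(-c2n[nH]cc2N2CCCNCC2)cc1`, differs from compound 3 by hydrogen in place of fluoro on an aromatic carbon. For the measured compounds named here, no measured step bears readably on this change, and compound 3 itself shows only a limit. The expectation is therefore that compound 4 also lands near the limit, with an expected step that the limit leaves unreadable from compound 3 to compound 4. Compound 4 is estimated at 15000 nM, within a range from 3000 nM to 80000 nM.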

Compound 4, inhibition constant: > 10000 nM
Compound 4: a limit, no number (the forecaster's own chance of this, stated with the estimate: 80%); the middle value lies beyond the limit too.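

For the compounds shown here, compound 4 also gives only a limit, so no step between it and compound 1, compound 2 or compound 3 can be read: the limit of > 10000 nM in this assay, at which 4 of the 4 values shown sit. The compounds shown leave open how strongly each binds and whether fluoro, chloro or hydrogen makes any difference.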